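Fluoro for Methyl, Tested on Two Related Cores

The compounds below may be only part of what the source reports. "The series", "measured", "known", "first", "only" and "open" are said of these compounds alone.

Compound 1 `C/C(=C\c1cc(-c2ccc(C)cc2)co1)C(N)=O` gives 12000 nM. Compound 2 `C/C(=C\c1cc(-c2ccc(F)cc2)co1)C(N)=O` gives 11800 nM. Compound 3 `C/C(=C\c1ccc(-c2ccc(C)cc2)o1)C(N)=O` gives 4590 nM.

These three numbers come from a functional assay on HeLa cells (Homo sapiens) for cytotoxicity, read by CCK-8 assay, with a stated time of 24 h; on this read-out lower numbers stand for stronger inhibition and higher numbers for weaker inhibition. Compound 1 and compound 2 share one core and differ only by fluoro in place of methyl on an aromatic carbon. That change made a 1.0-fold lower number from compound 1 to compound 2 (0.01 log units; within the scatter), so the two numbers are indistinguishable here. Compound 3 has the same atoms as compound 1 joined differently; the difference between the two cores is not broken down here. Compound 3 has the lowest number of the three, and its gap to compound 1 and to compound 2 lies beyond the scatter, so among these three it is the strongest in this assay.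

Compound 4 `C/C(=C\c1ccc(-c2ccc(F)cc2)o1)C(N)=O` is not yet measured. It differs from compound 3 by fluoro in place of methyl on an aromatic carbon, the same change as that from compound 1 to compound 2, at the same kind of place. The expectation rests on that earlier step: because a 1.0-fold lower number from compound 1 to compound 2 (0.01 log units; within the scatter) stayed within the scatter, compound 4 is expected to move only a 1.0-fold lower number from compound 3 to compound 4 (0.01 log units; within the scatter). Compound 4 is therefore estimated at 4500 nM in this assay, with a range expected between 2300 nM and 9000 nM.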

Compound 4, half-maximal inhibitory concentration: 2030 nM
Compound 4: middle estimate off by 2.2-fold (0.35 log units), on the high side; measured number below the stated range.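

In this assay, putting fluoro in place of methyl on the second core gave a 2.3-fold lower number from compound 3 to compound 4 (0.35 log units; beyond the scatter), a modest step, whereas the same change on the first core left the number essentially unmoved. Set side by side, these two results do not differ by more than repeated measurements of such steps would be expected to, so the data give no firm sign that the core alters the outcome of this change: the same change on two cores in this assay, a 1.0-fold lower number (0.01 log units; within the scatter) from compound 1 to compound 2 and a 2.3-fold lower number (0.35 log units; beyond the scatter) from compound 3 to compound 4, 2.2-fold (0.35 log units) apart, within the scatter of two such steps. This does not show that the change acts identically on both cores, as a single step on each cannot exclude a real but small difference, and the agreement covers only these two cores in this one assay.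

The compounds shown carry only methyl or fluoro at this place, so it remains open how a chloro, a methoxy or an amine there would behave on either core. Also open, from the compounds shown here alone, is whether the step would hold if a carboxylic acid took the place of the amide.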